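Exchanging One Aromatic Group on Compound 1

A few compounds are considered here, and "the series" means these few. Any claim that something is new, unique, unknown or untested is made for them only; others in the source may bear on it.

For the measured compounds named here, in an ADME assay on Vero cells (Chlorocebus sabaeus) for cytotoxicity, read by MTT assay, with a stated time of 48 h (a higher number here means a weaker inhibitor, a lower number a stronger inhibitor), compound 1 (`CC#CCn1c(N2CCC[C@@H](N)C2)nc2c1c(=O)n(CCCN1CCN(c3nc(-c4ccccc4)cs3)CC1)c(=O)n2C`) gives 4.3 ug/mL and stands lowest of the two measured so far, while compound 2 (`CC#CCn1c(N2CCC[C@@H](N)C2)nc2c1c(=O)n(CCCN1CCC(n3cc(-c4ccccc4)nn3)CC1)c(=O)n2C`) gives 25.9 ug/mL and lies beyond the usual scatter from it. Compound 3 (`CC#CCn1c(N2CCC[C@@H](N)C2)nc2c1c(=O)n(CCCN1CCN(c3noc(-c4ccccc4)n3)CC1)c(=O)n2C`) carries 5-phenyl-1,2,4-oxadiazol-3-yl in place of 4-phenyl-1,3-thiazol-2-yl on an amine nitrogen in a ring. Going by the values given here, no measured step covers this exchange, so the guide is thin. In this assay the expected change is a modest rise, estimated as a 2.3-fold higher number from compound 1 to compound 3 (0.37 log units; beyond the scatter) and only slightly beyond the scatter. Compound 3 is expected at an estimated 10 ug/mL (3.5 ug/mL to 30 ug/mL).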

Compound 3, half-maximal inhibitory concentration: 8.7 ug/mL
Compound 3: middle estimate off by 1.1-fold (0.06 log units), on the high side; the measured number falls inside the stated range.
By their numbers in this assay, from the lowest: compound 1; then compound 3; then compound 2.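

For the compounds shown here, at this position, on an amine nitrogen in a ring, the first one-place step in this assay is a 2.0-fold higher number from compound 1 to compound 3 (0.31 log units; beyond the scatter) and is modest. It shows that replacing 4-phenyl-1,3-thiazol-2-yl with 5-phenyl-1,2,4-oxadiazol-3-yl, which changes the hetero atoms of the five-membered aromatic ring, shifts the number only slightly beyond the usual scatter. Nothing available explains this shift.

The compounds shown leave open how the number would respond to an amine or a carboxylic acid on the phenyl ring. A simple methyl in place of the whole aromatic group also remains an open case.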